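The compounds below may be only part of what the source reports. "The series", "measured", "known", "first", "only" and "open" are said of these compounds alone.

Measured so far:
compound 1, `O[C@@]1(c2ccccn2)CC[C@@H](c2ccc(C(F)(F)F)cc2)C1`, 240 nM
compound 2, `C[C@]1(O)C[C@](c2ccc(OC(F)(F)F)cc2)([C@H](O)c2ccccn2)C1`, 1510 nM

In an assay on HEK293 cells for antagonist activity at transient receptor potential cation channel subfamily V member 3 (Homo sapiens), read by FLIPR and calcium flux (on this read-out higher numbers stand for weaker inhibition and lower numbers for stronger inhibition), compound 1 gives 240 nM, the lowest of the two numbers shown, and the gap to compound 2, which gives 1510 nM in this assay, lies beyond the usual scatter. Compound 3, `O[C@]1(c2ccccn2)CC[C@H](c2ccc(C(F)(F)F)cc2)C1`, has not yet been measured. It differs from compound 1 in this way: the two compounds have the same atoms and bonds and differ only in configuration as drawn: 2 of 2 stereo elements differ (all stereocentres are inverted: mirror images); a stereocentre at a saturated ring carbon is drawn S in compound 1 and R in compound 3; a stereocentre at a saturated ring carbon is drawn R in compound 1 and S in compound 3. Among the measured compounds shown here, no measured pair in this set shows how such a change plays out, so no measured step can be borrowed. Mirror images of a compound frequently do not inhibit equally, and one of the two often gives a clearly higher number. With compound 1 already the more active of the pair shown, the expectation is a step toward weaker inhibition, larger than the scatter but uncertain in size; the expected step is a 6.3-fold higher number from compound 1 to compound 3 (0.80 log units; beyond the scatter). Compound 3 is therefore estimated at 1500 nM in this assay, within a range from 300 nM to 8000 nM.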

Compound 3, antagonist equilibrium constant: 540 nM
Beside the measured number, compound 3's estimate is 2.8-fold (0.44 log units) above it, and the stated range covers the measured number.
By their numbers in this assay, from the lowest: compound 1; then compound 3; then compound 2.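

In this assay, inverting both stereocentres gives a 2.3-fold higher number from compound 1 to compound 3 (0.35 log units; beyond the scatter), a modest but real preference for one mirror image. Among the compounds shown here, compound 1 and compound 2 differ in several places at once, so this is the first pair in which the effect of three-dimensional arrangement stands alone. The gap cannot be traced to any added or removed group, because nothing separates the pair except their spatial arrangement: the fact that compounds 1 and 3 differ only in the configuration as drawn

On these data alone, how much each stereocentre contributes on its own stays open, as both change together here. Also open, as far as these compounds go, is whether the same preference would hold with a nitrile in place of the trifluoromethyl group, or with an amine in place of the hydroxyl group.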